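This account rests on a few compounds, and the source may have more. Where it says the series, first, only, none or still open, it means among the compounds named here.

Measured so far in an assay on CHO cells for binding affinity to 5-hydroxytryptamine receptor 1B (Homo sapiens); a lower number here means a stronger inhibitor, a higher number a weaker inhibitor:
compound 1 `CN(Cc1ccccc1)CC1CCN(CCCc2c[nH]c3ccc(-n4cnnc4)cc23)CC1`: 28 nM
compound 2 `c1ccc(CNC2CCN(CCCc3c[nH]c4ccc(-n5cnnc5)cc34)CC2)cc1`: 125 nM

On these two numbers compound 2 stands highest. Within the data shown here, the only measured step is a 4.5-fold higher number from compound 1 to compound 2 (0.65 log units; beyond the scatter), a modest one. Compound 3 `C[C@@H](NC1CCN(CCCc2c[nH]c3ccc(-n4cnnc4)cc23)CC1)c1ccccc1` carries methyl in place of hydrogen on a saturated chain carbon bound to an amine nitrogen and an aromatic carbon. Among the measured compounds shown here, that step from compound 1 to compound 2 alters the amine substitution on the saturated ring carbon, not the chain carbon changed here, so no measured step bears on this change. No step beyond the scatter in this assay is expected in either direction. Compound 3 is estimated at 125 nM, within a range of 40 nM to 400 nM. This amounts to an expected step of no change at the digits printed from compound 2 to compound 3 (within the scatter).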

Compound 3, half-maximal inhibitory concentration: 35 nM
The estimate for compound 3 lay 3.6-fold (0.55 log units) above the measured number; the whole stated range lies above it.
By their numbers in this assay, from the lowest: compounds 1 and 3 (each within the scatter of the next); then compound 2.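

In this assay, methyl in place of hydrogen on a saturated chain carbon bound to an amine nitrogen and an aromatic carbon is not a silent change: a 3.6-fold lower number from compound 2 to compound 3 (0.55 log units; beyond the scatter). The (1-phenylethyl)amino group also cannot be told apart from the (benzyl(methyl)amino)methyl group, with a 1.3-fold higher number from compound 1 to compound 3 (0.10 log units; within the scatter). Nothing available accounts for the methyl step.

Only one configuration at this carbon is shown, so the opposite one remains open. As far as these compounds go, whether an ethyl group or a second methyl on this carbon would keep the lower number also remains open.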